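Diaryl urea pyrazoles: a dichlorophenyl swap on the urea

The source may report more compounds than this note shows. Statements on the series, on what has been measured and on what is new or still open speak of the compounds shown alone.

Two members of the series have been run through a functional assay on PC-3 cells (Homo sapiens) for inhibition, read by sulforhodamine B assay, with a stated time of 48 h, tested at 10 uM; on this read-out higher numbers stand for a weaker effect at the one concentration tested and lower numbers for a stronger effect. Compound 1 `COc1cc(Cl)cc(-c2nn(-c3cccc(NC(=O)Nc4cccc(C(F)(F)F)c4)c3)cc2-c2ccncc2)c1` gives -9.92% there, and compound 2 `O=C(Nc1cccc(-n2cc(-c3ccncc3)c(-c3cc(O)cc(Cl)c3)n2)c1)Nc1ccc(Cl)c(Cl)c1` gives -1.66%. Compound 1 holds the lowest of the two numbers, but the gap to compound 2 lies within the scatter, so the two readings cannot be set in order against each other; both sit at or close to no measurable effect at the single concentration tested.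

Compound 3 `COc1cc(Cl)cc(-c2nn(-c3cccc(NC(=O)Nc4ccc(Cl)c(Cl)c4)c3)cc2-c2ccncc2)c1` has not yet been measured in this assay. Relative to compound 1 the change is 3,4-dichlorophenyl in place of 3-(trifluoromethyl)phenyl on an amide-type nitrogen. The rest of the molecule, the shared core with its methoxy-chlorophenyl and pyridyl groups, is untouched. Among the measured compounds shown here, compound 2 already carries the 3,4-dichlorophenyl on its urea, though with a hydroxy in place of the methoxy, and its reading sits within the scatter of compound 1, so no step between the two measured compounds is available to guide the size of this change.

The expected step from compound 1 to compound 3 is a number 5.9 percentage points higher from compound 1 to compound 3 (within the scatter), that is, no movement beyond the scatter. Compound 3 is estimated at -4%, with a range from -18% to 10%.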

Compound 3, a percentage reported as activity, at one concentration (the size of the read-out at that concentration, not a potency): -5.03%
For compound 3 the middle estimate is 1 percentage points above the measured one; measured number inside the range.
By their numbers in this assay, from the lowest: compounds 1, 3 and 2 (each within the scatter of the next).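

In this assay, 3,4-dichlorophenyl in place of 3-(trifluoromethyl)phenyl on the amide-type nitrogen gives a number 4.9 percentage points higher from compound 1 to compound 3 (within the scatter). Among the compounds shown here, this provides the first single-change reading at this position, and at the one concentration tested it does not separate the two aryl groups. The earlier pair differed in more than one place, whereas methyl in place of hydrogen on the oxygen on the aromatic ring can now be read alone as a number 3.4 percentage points lower from compound 2 to compound 3 (within the scatter), which likewise shows no separation. No independent measurement is at hand to explain either reading.

For the compounds shown here, all three readings sit at or close to no measurable effect, so these steps show only that neither change produces a measurable effect from this starting point, not how either change would act in a compound with a clear effect in this assay. Still open, going by these compounds, is the outcome with a phenyl carrying an amine or a carboxylic acid on the amide-type nitrogen, or with a longer chain in place of the methyl on the oxygen.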